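Dropping the 5-chloropyridin-2-yl group from compound 2

The compounds below may be only part of what the source reports. "The series", "measured", "known", "first", "only" and "open" are said of these compounds alone.

Within the data shown here, in a physicochemical assay for permeability, using PAMPA (on this read-out higher numbers stand for higher permeability and lower numbers for lower permeability), compound 2 `C[C@@H](Oc1cc2oc(=O)n(CCC(=O)O)c2cc1Cl)c1ccc(Cl)cn1` gives 60 nm/s, the higher of the two numbers so far, while compound 1 `Cc1ccc([C@@H](C)Oc2cc3oc(=O)n(CCC(=O)O)c3cc2Cl)nc1` gives 22 nm/s. Compound 3 `CCOc1cc2oc(=O)n(CCC(=O)O)c2cc1Cl` has not yet been measured. Going from compound 2 to compound 3 changes the structure as follows: hydrogen in place of 5-chloropyridin-2-yl on a saturated chain carbon bound to an oxygen on an aromatic ring and a saturated chain carbon. In words, hydrogen takes the place of 5-chloropyridin-2-yl on a saturated chain carbon bound to an oxygen on an aromatic ring and a saturated chain carbon.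

Among the measured compounds shown here, only one measured step bears on this, and only indirectly: a 2.7-fold higher number from compound 1 to compound 2 (0.44 log units; beyond the scatter), with chloro in place of methyl on an aromatic carbon. For the measured compounds named here, no measured compound lacks the whole group, so the direction remains a judgement. Losing that group is a much larger edit, so a drop of at least similar size seems likely. The expected change is a 3.3-fold lower number from compound 2 to compound 3 (0.52 log units; beyond the scatter). For compound 3 the estimated value is 18 nm/s, with an expected range of 5 nm/s to 55 nm/s.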

Compound 3, apparent permeability: < 10 nm/s
Compound 3: only a limit was reported; the forecaster's own chance of this, stated with the estimate: 10%; middle value at least 1.8-fold (0.25 log units) from the limit.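

In this assay, compound 3 carries only a limit and not a number: the limit of < 10 nm/s in this assay, at which 1 of the 3 values shown sits.

Even so, replacing the 5-chloropyridin-2-yl group with hydrogen gives an at least 6.0-fold lower number from compound 2 to compound 3 (0.77 log units; beyond the scatter), and replacing the 5-methylpyridin-2-yl group with hydrogen gives an at least 2.2-fold lower number from compound 1 to compound 3 (0.34 log units; beyond the scatter). The earlier pair varied only one substituent on the pyridine ring, whereas these steps show that, with either substituent, the compound keeping the ring at this saturated chain carbon gives the higher number.

The compounds shown leave open whether the pyridine ring's nitrogen plays any part in this, which a phenyl ring at the same place would test. They also leave open whether a small group without a ring, such as a cyclopropyl or a methoxy group, would give a number closer to those of the pyridine compounds.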